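The source may hold more compounds than are shown below. What is called first, only, known or untested is meant among the compounds shown, and "the series" means these compounds.

Measured compounds in an ADME assay on cells (Hepatocyte, Homo sapiens) for metabolic stability, read by LC-MS, with a stated time of 60 min, tested at 1 uM; on this read-out higher numbers stand for fast clearance and lower numbers for slow clearance:
compound 1 `COc1cc(N(CC2CC2)c2ccc(Cl)c(Cl)c2)cnc1C(=O)[C@H]1C[C@@H]1C(=O)O` gives 4.3 uL/min;
compound 2 `COc1cc(N(CC2CC2)c2ccccc2)cnc1C(=O)[C@H]1C[C@@H]1C(=O)O` gives 3 uL/min;
compound 3 `COc1cc(N(CC2CC2)c2ccc(F)c3ccccc23)cnc1C(=O)[C@H]1C[C@@H]1C(=O)O` gives 5.4 uL/min.

Compound 2 is one of three compounds whose numbers all lie within the usual scatter of one another. The step of a 1.4-fold lower number from compound 1 to compound 2 (0.16 log units; within the scatter) shows this directly, and the gap between compound 2 and compound 3 is also within the scatter, so on the numbers in hand none of the three can be told apart in this assay.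

Compound 4 `COc1cc(N(CC2CC2)c2cccc(C(F)(F)F)c2)cnc1C(=O)[C@H]1C[C@@H]1C(=O)O` differs from compound 2 in a single place: trifluoromethyl in place of hydrogen on an aromatic carbon. Among the measured compounds shown here, the one measured step that bears on such a change is a 1.4-fold lower number from compound 1 to compound 2 (0.16 log units; within the scatter), in which the whole aryl ring on the nitrogen is exchanged without a shift beyond the scatter; compound 3 carries yet another aryl ring and its number falls in the same narrow band. Exchanging the ring attached to that nitrogen has so far left this assay essentially unmoved, and the smaller change of adding a trifluoromethyl group offers no reason to expect more.

For compound 4 the expected step is a 1.3-fold higher number from compound 2 to compound 4 (0.12 log units; within the scatter), which is expected to remain within the scatter. Compound 4 is therefore estimated at 4 uL/min, with a likely range from 2 uL/min to 8 uL/min.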

Compound 4, intrinsic clearance in a liver preparation (reported as CLH), per the amount of preparation that the assay uses: 2.3 uL/min
Estimate against measurement, compound 4: 1.7-fold (0.24 log units) above; measured number inside the range.
By their numbers in this assay, from the lowest: compounds 4, 2, 1 and 3 (each within the scatter of the next, the first and the last beyond it).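

In this assay, adding trifluoromethyl to an aromatic carbon of the phenyl ring on the nitrogen, meta to a large group, gives a 1.3-fold lower number from compound 2 to compound 4 (0.12 log units; within the scatter) and so stays within the scatter. Among the compounds shown here, this is the first reading of a single group added to that ring, whereas the earlier step exchanged one whole aryl ring for another, and it shows that this addition of four heavy atoms leaves the clearance reading indistinguishable from that of the plain phenyl ring. The exchange of 3,4-dichlorophenyl for 3-(trifluoromethyl)phenyl gives a 1.9-fold lower number from compound 1 to compound 4 (0.27 log units; within the scatter) and also stays within the scatter, so these two substituted rings cannot be told apart here, and no measurement on hand offers a cause for either result.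

Going by these compounds, all the groups added to this ring so far are halogens, trifluoromethyl or a fused benzene ring, so it remains open whether an amine or a carboxylic acid on the ring would shift the number beyond the scatter. On these data alone, it also remains open whether a longer chain as the other substituent on that nitrogen would do so.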